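A few compounds are considered here, and "the series" means these few. Any claim that something is new, unique, unknown or untested is made for them only; others in the source may bear on it.

Measured so far in an in vitro functional assay on 1321-N1 cells for agonist activity at Free fatty acid receptor 1 (Homo sapiens), read by fluorescence, spectrophotometry and calcium flux; a higher number here means a larger maximal response, a lower number a smaller maximal response:

compound 1, `Cc1cc(C#Cc2ccc(CCC(=O)O)cc2)nc(Cl)n1`: 110%
compound 2, `O=C(O)CCc1ccc(C#Cc2ncccc2[N+](=O)[O-])cc1`: 87%
compound 3, `O=C(O)CCc1ccc(C#Cc2ccnc(F)c2)cc1`: 98%

Compound 3 stands second highest of the three numbers. Its nearest neighbour is compound 2, whose value lies lower by a gap beyond the scatter; the furthest is compound 1, whose value lies higher, also beyond the scatter. Going by the values given here, no two of the measured compounds differ in a single place, so no measured step is available.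

Compound 4, `O=C(O)CCc1ccc(C#Cc2ccnc(Cl)c2)cc1`, has not yet been measured. Against compound 3 the change is chloro in place of fluoro on an aromatic carbon. The exchange is a single heavy atom on the same aromatic carbon, with no change in ring, donors, acceptors or charge. Compound 1 also carries a chloro group on a ring with nitrogen and gives 110%, but its ring differs from that of compound 3 in more than one place, so it does not supply a step for this exchange.

The step expected in this assay is small, at most modestly upward and possibly none beyond the scatter; the estimated step is a number 3 percentage points higher from compound 3 to compound 4 (within the scatter). For compound 4 the expected value is 101%, with a range from 86% to 116%.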

Compound 4, largest response reached (reported as efficacy), in percent of the reference or control that the assay uses: 94%
Estimate against measurement, compound 4: 7 percentage points above; the measured number falls inside the stated range.
By their numbers in this assay, from the lowest: compounds 2, 4 and 3 (each within the scatter of the next, the first and the last beyond it); then compound 1.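

Chloro in place of fluoro on this aromatic carbon, next to the ring nitrogen, gives a number 4 percentage points lower from compound 3 to compound 4 (within the scatter) in this assay and provides the first single-place step in the series. Going by these compounds alone, the maximal response therefore does not separate these two halogens at this position, which the earlier compounds could not show because no two of them differed in only one place. No measurement shown here bears on why the two halogens read alike.

Still open, going by these compounds, is whether the response holds at this carbon with a group other than a halogen, such as a methoxy, a nitrile or an amine in place of chloro, each of which would give another single-place comparison on the same core. Also open is whether the same exchange of fluoro for chloro gives a similar step on the core of compound 1 or compound 2, and the numbers shown speak only to maximal response, not to the concentration needed to reach it.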